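Swapping a Cyclopentyl Ring for a Hydroxymethylpropyl Chain

The source may report more compounds than this note shows. Statements on the series, on what has been measured and on what is new or still open speak of the compounds shown alone.

Three compounds share one core and differ only in the group carried on the amide-type nitrogen. Compound 1 `COCCNC(=O)c1cc2cccc(OC)c2oc1=N` gives 43% in an assay on HEK293 cells for displacement of a labelled ligand from adenosine receptor A2b (Homo sapiens), read by scintillation counting, with a stated time of 30 min, tested at 10 uM; a higher number here means more inhibition at the concentration tested (going by the name of the read-out), a lower number less inhibition. Compound 2 `COc1cccc2cc(C(=O)NCCO)c(=N)oc12` gives 65% in this assay, and compound 3 `COc1cccc2cc(C(=O)NC3CCCC3)c(=N)oc12` gives 47%. Compound 3 therefore stands second of the three: its number sits within the scatter of compound 1, as a number 4 percentage points higher from compound 1 to compound 3 (within the scatter) shows, while a number 18 percentage points lower from compound 2 to compound 3 (beyond the scatter) is a modest fall that lies beyond it.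

Compound 4 `CCC(CO)NC(=O)c1cc2cccc(OC)c2oc1=N` has not yet been measured. It differs from compound 3 in one place: 1-(hydroxymethyl)propyl in place of cyclopentyl on an amide-type nitrogen. The step that bears most on this change is a number 18 percentage points lower from compound 2 to compound 3 (beyond the scatter), in which a chain carrying one hydrogen-bond donor gave way to the cyclopentyl ring and inhibition fell modestly; compound 4 brings such a chain back. The step of a number 22 percentage points higher from compound 1 to compound 2 (beyond the scatter), which introduced a hydrogen-bond donor on the chain, points the same way, whereas a number 4 percentage points higher from compound 1 to compound 3 (within the scatter), which exchanged a donor-free chain for the ring, stayed within the scatter. A modest rise beyond the scatter is therefore expected for compound 4, a number 11 percentage points higher from compound 3 to compound 4 (beyond the scatter). Compound 4 is estimated at 58%, with a range from 42% to 72%.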

Compound 4, a percentage reported as inhibition, at one concentration (the size of the read-out at that concentration, not a potency): 39%
Beside the measured number, compound 4's estimate is 19 percentage points above it; measured number below the stated range.
By their numbers in this assay, from the lowest: compounds 4, 1 and 3 (each within the scatter of the next); then compound 2.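

The hydrogen-bond donor alone does not decide the outcome at this position: in this assay, 1-(hydroxymethyl)propyl in place of cyclopentyl gives a number 8 percentage points lower from compound 3 to compound 4 (within the scatter) and so does not recover the number of compound 2. The decisive contrast is a number 26 percentage points lower from compound 2 to compound 4 (beyond the scatter), a step that adds only ethyl in place of hydrogen on the saturated chain carbon bound to the amide-type nitrogen, so the same donor-bearing chain gives a clearly different result once that ethyl is present. Set against the 2-methoxyethyl chain, which has no donor, the new chain gives a number 4 percentage points lower from compound 1 to compound 4 (within the scatter), which leaves compound 2 as the only one of the four whose number stands apart, while a ring, a donor-free chain and a branched donor-bearing chain all fall within the scatter of the next in the ranking.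

Nothing available explains why the ethyl branch makes this difference. From the compounds shown here alone, it also remains open whether methyl in place of the ethyl would keep the number near that of compound 2 or compound 4, and whether an amine in place of the hydroxyl on the unbranched chain would hold up.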